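The source may hold more compounds than are shown below. What is called first, only, known or untested is meant among the compounds shown, and "the series" means these compounds.

Of the compounds shown here, three have been tested in a functional assay on the whole organism (strain albino) for inhibition, with Rattus norvegicus as the target, read by paw edema, with a stated time of 5 h, at a dose of 0.28 mmol/kg by the oral route; on this read-out lower numbers stand for less inhibition and higher numbers for more inhibition at the one dose given (going by the name of the read-out). Compound 1 `C=CCn1c(SCC(=O)c2ccccc2)nnc1-c1ccccc1` gives 66% in this assay, compound 2 `C=CCn1c(SCC(=O)c2ccccc2)nnc1-c1ccc(OC)cc1` gives 61%, and compound 3 `CCn1c(SC/C(=N/O)c2ccccc2)nnc1-c1ccc(OC)cc1` gives 71%. The difference between the core of compound 2 and the core of compound 3 is not broken down here. Compound 2 and compound 1 differ in one place, (hydrogen in place of methoxy on an aromatic carbon), and that change brought a number 5 percentage points higher from compound 2 to compound 1 (within the scatter). Compound 4 `CCn1c(SC/C(=N/O)c2ccccc2)nnc1-c1ccccc1` has not yet been measured; it differs from compound 3 by the same change, (hydrogen in place of methoxy on an aromatic carbon), at a place described in the same words. On the strength of the earlier step of a number 5 percentage points higher from compound 2 to compound 1 (within the scatter), which lay within the scatter, the expected step is a number 2 percentage points higher from compound 3 to compound 4 (within the scatter). Compound 4 is therefore expected to give about 73% in this assay, most likely between 61% and 83%.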

Compound 4, a percentage reported as inhibition, in the whole organism at one dose (the size of the read-out at that dose, not a potency): 71%
Compound 4: middle estimate off by 2 percentage points, on the high side, within the range that was stated.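

In this assay the change from 4-methoxyphenyl to phenyl gives no change at the digits printed from compound 3 to compound 4 (within the scatter), and the two cores agree as far as these numbers can tell: the same change on two cores in this assay, a number 5 percentage points higher (within the scatter) from compound 2 to compound 1 and no change at the digits printed (within the scatter) from compound 3 to compound 4, 5 percentage points apart, within the scatter of two such steps.
So in this small set, the swap can be carried from one core to the other with no step beyond the scatter. It does not show that the swap has any real effect on either core, and two cores cannot show that the same would hold on a third.

The compounds shown leave open whether another group at this place on the ring, such as an amine or a carboxylic acid, would move the number beyond the scatter. They also leave open whether the swap would stay this small at another dose.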